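A few compounds are considered here, and "the series" means these few. Any claim that something is new, unique, unknown or untested is made for them only; others in the source may bear on it.

Measured in a functional assay on HeLa S3 cells (Homo sapiens) for antiproliferative activity, read by XTT assay, with a stated time of 72 h (a lower number here means a stronger inhibitor, a higher number a weaker inhibitor), so far:
- compound 1 `C#Cc1cn([C@@H]2O[C@H](CO)[C@@H](O)[C@H]2O)c2ncnc(SC)c12` gives 110 nM (ethynyl, methylsulfanyl)
- compound 2 `C#Cc1cn([C@@H]2O[C@H](CO)[C@@H](O)[C@H]2O)c2ncnc(N(C)C)c12` gives 810 nM (ethynyl, dimethylamino)
- compound 3 `Cc1ncnc2c1c(-c1cccs1)cn2[C@@H]1O[C@H](CO)[C@@H](O)[C@H]1O` gives > 15000 nM (a limit, not a number)

Compound 3 stands at the limit of > 15000 nM in this assay, at which 1 of the 3 values shown sits, and so has no number. The next compound is compound 4 `C#Cc1cn([C@@H]2O[C@H](CO)[C@@H](O)[C@H]2O)c2ncnc(C)c12`, which carries ethynyl in place of thiophen-2-yl on an aromatic carbon.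

For the measured compounds named here, no measured step makes this exchange. Going by the values given here, the one measured step is a 7.4-fold higher number from compound 1 to compound 2 (0.87 log units; beyond the scatter) and it keeps the ethynyl group, so it bears on this change only indirectly. It shows how far values can move among compounds that carry ethynyl. Both such compounds give real numbers in this assay, and compound 2 has the higher of the two at 810 nM. Compound 4 differs from both in its other group, so its value is uncertain.

A large move to a lower number is therefore expected, though its size is loosely fixed since it starts from a limit. The estimated step is an at least 50-fold lower number from compound 3 to compound 4 (1.69 log units; beyond the scatter) (at the least a clear drop). For compound 4 the expected value is 300 nM, with an estimated range from 60 nM to 1500 nM (the span of a wide guess).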

Compound 4, half-maximal inhibitory concentration: 14700 nM
Beside the measured number, compound 4's estimate is 49-fold (1.69 log units) below it; the measured number lies above the stated range.
By their numbers in this assay, from the lowest: compound 1; then compound 2; then compound 4. At a limit, above all of these: compound 3.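

In this assay, the exchange of thiophen-2-yl for ethynyl, with methyl kept as the other group, gives an at least 1.0-fold lower number from compound 3 to compound 4 (0.00 log units; that floor lies within the scatter), so with methyl in that other place ethynyl brings no change that can be told from the scatter. Compound 3 stands at a limit and not at a number, so the step has only a floor: the limit of > 15000 nM in this assay, at which 1 of the 4 values shown sits.

With ethynyl kept, the other group proves the larger lever in these compounds: methyl in place of dimethylamino gives an 18-fold higher number from compound 2 to compound 4 (1.26 log units; beyond the scatter), and methyl in place of methylsulfanyl gives a 130-fold higher number from compound 1 to compound 4 (2.13 log units; beyond the scatter), so ethynyl alone does not carry the lower numbers of compound 1 and compound 2.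

The compounds shown leave open how thiophen-2-yl compares with ethynyl when methylsulfanyl or dimethylamino is the other group, since thiophen-2-yl appears here only with methyl. They also leave open whether a methoxy group or an unsubstituted amine on that aromatic carbon would give a number nearer to that of compound 1 or to that of compound 4.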